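This account rests on a few compounds, and the source may have more. Where it says the series, first, only, none or still open, it means among the compounds named here.

In a functional assay on HL-60 cells (Homo sapiens) for antiproliferative activity, read by XTT assay, with a stated time of 72 h (on this read-out higher numbers stand for weaker inhibition and lower numbers for stronger inhibition), two compounds of this series have been measured so far. Compound 1 `C#Cc1cn([C@@H]2O[C@H](CO)[C@@H](O)[C@H]2O)c2ncnc(N(C)C)c12` gives 290 nM in this assay. Compound 2 `Cc1ncnc2c1c(-c1cccs1)cn2[C@@H]1O[C@H](CO)[C@@H](O)[C@H]1O` gives 5730 nM in this assay, the higher of the two numbers, and its gap to compound 1 lies beyond the scatter. Within the data shown here, compound 1 and compound 2 differ in more than one place, so no single step joins them. Compound 3 `CN(C)c1ncnc2c1c(-c1cccs1)cn2[C@@H]1O[C@H](CO)[C@@H](O)[C@H]1O` has not yet been measured in this assay. It differs from compound 2 in one place: dimethylamino in place of methyl on an aromatic carbon. As a reason for an expectation, compound 1, which also carries a dimethylamino group, gives 290 nM, a lower number than compound 2, though its second difference from compound 2 leaves the share of the dimethylamino group unresolved. Compound 3 is therefore expected to show a step of a 4.8-fold lower number from compound 2 to compound 3 (0.68 log units; beyond the scatter) toward a lower number, beyond the scatter. The estimate for compound 3 in this assay is 1200 nM, within a range from 300 nM to 5000 nM.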

Compound 3, half-maximal inhibitory concentration: 11800 nM
Compound 3: the middle estimate sits 9.8-fold (0.99 log units) below what was measured; the measured number lies above the stated range.
By their numbers in this assay, from the lowest: compound 1; then compound 2; then compound 3.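

In this assay dimethylamino in place of methyl on this aromatic carbon, with thiophen-2-yl kept in the other place, gives a 2.1-fold higher number from compound 2 to compound 3 (0.31 log units; beyond the scatter) and so does not bring the lower number that the earlier pair had left possible. Thiophen-2-yl in place of ethynyl, with dimethylamino kept, gives a 41-fold higher number from compound 1 to compound 3 (1.61 log units; beyond the scatter) and is by far the larger of the two steps, so among these three compounds the low number of the ethynyl compound goes with the ethynyl group and not with dimethylamino. Nothing given here explains either step.

From the compounds shown here alone, whether dimethylamino in place of methyl gives a step of the same direction and size when ethynyl is present remains open. So does what a primary amine or a methoxy group would give on this aromatic carbon.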